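Amino for Hydroxy: Cytotoxicity Estimate for Compound 4

A few compounds are considered here, and "the series" means these few. Any claim that something is new, unique, unknown or untested is made for them only; others in the source may bear on it.

Compound 1, `Oc1ccc(-c2cccc(O)c2)cc1`: 31 ug/mL
Compound 2, `Nc1ccc(-c2cccc(O)c2)cc1`: 55 ug/mL
Compound 3, `COc1ccc(-c2cccc(O)c2)c(OC)c1`: 28 ug/mL

These three compounds were measured in an ADME assay on HEK293 cells (Homo sapiens) for cytotoxicity, read by MTT assay, with a stated time of 3 days; a lower number here means a stronger inhibitor, a higher number a weaker inhibitor. Compound 2 differs from compound 1 by amino in place of hydroxy on an aromatic carbon, and that change gave a 1.8-fold higher number from compound 1 to compound 2 (0.25 log units; within the scatter). Compound 3 and compound 1 differ in their cores; the difference between the two cores is not broken down here. Compound 4, `COc1ccc(-c2cccc(N)c2)c(OC)c1`, has not yet been measured. It differs from compound 3 by amino in place of hydroxy on an aromatic carbon. This is the same kind of change as from compound 1 to compound 2, though the place differs: in one case para to a group of 7 heavy atoms, in the other meta to a large group. Because a 1.8-fold higher number from compound 1 to compound 2 (0.25 log units; within the scatter) was seen for this change, compound 4 is expected to give a 1.8-fold higher number from compound 3 to compound 4 (0.25 log units; within the scatter) in this assay. The estimate for compound 4 is 50 ug/mL, expected to fall between 25 ug/mL and 100 ug/mL.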

Compound 4, half-maximal inhibitory concentration: 29.2 ug/mL
Estimate against measurement, compound 4: 1.7-fold (0.23 log units) above; the range from low to high includes it.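

In this assay amino in place of hydroxy gave a 1.0-fold higher number from compound 3 to compound 4 (0.02 log units; within the scatter) on the core of compound 3, and this agrees with the earlier step on the core of compound 1: the same change on two cores in this assay, a 1.8-fold higher number (0.25 log units; within the scatter) from compound 1 to compound 2 and a 1.0-fold higher number (0.02 log units; within the scatter) from compound 3 to compound 4, 1.7-fold (0.23 log units) apart, within the scatter of two such steps.

On these two cores, then, the change carried over without a difference beyond the scatter. Neither step lies beyond the scatter, so the two pairs do not show that the change has any effect, and they cannot show how it would behave on a further core.

The compounds shown leave open how a carboxylic acid, an amide or a longer chain would read at this place in this assay.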